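Notes on a methoxy group added to the pentyl chain

The compounds below may be only part of what the source reports. "The series", "measured", "known", "first", "only" and "open" are said of these compounds alone.

Of the compounds shown here, two carry numbers so far. In a functional assay on MCF7 cells (Homo sapiens) for antiproliferative activity, with a stated time of 48 h (a lower number here means a stronger inhibitor, a higher number a weaker inhibitor), compound 1 (`CC(C)(C)c1ccc(NC(=O)NCCCCl)cc1`) gives 49000 nM and compound 2 (`CCCCCc1cccc(NC(=O)NCCCCl)c1`) gives 26000 nM and these two values lie within the scatter of each other, so compound 2 cannot be told apart from compound 1 on these numbers.

Compound 3 (`CCCCC(OC)c1cccc(NC(=O)NCCCCl)c1`) differs from compound 2 in one place only. The change is methoxy in place of hydrogen on a saturated chain carbon bound to an aromatic carbon and a saturated chain carbon and it puts methoxy in place of hydrogen on a saturated chain carbon bound to an aromatic carbon and a saturated chain carbon, so that pentyl becomes 1-methoxypentyl.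

Going by the values given here, no measured pair differs in a single place, so the data give no direct guide to the size of this step. With that gap in mind, no step beyond the scatter is expected in this assay in either direction. The estimated change is a 1.1-fold lower number from compound 2 to compound 3 (0.03 log units; within the scatter) and it is expected to remain small. For compound 3 the expected value is 24000 nM with an estimated range from 10000 nM to 60000 nM as the likely span.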

Compound 3, half-maximal inhibitory concentration: 50000 nM
Estimate against measurement, compound 3: 2.1-fold (0.32 log units) below, and the stated range covers the measured number.
By their numbers in this assay, from the lowest: compounds 2, 1 and 3 (each within the scatter of the next).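

In this assay, the series now has its first pair differing in one place, and it reads a 1.9-fold higher number from compound 2 to compound 3 (0.28 log units; within the scatter). At this saturated chain carbon bound to an aromatic carbon and a saturated chain carbon, the replacement of hydrogen by methoxy, which turns pentyl into 1-methoxypentyl, therefore leaves compound 3 indistinguishable from compound 2 on these numbers, and this single pair gives no sign that the position is sensitive to this change. No accompanying measurement bears on what lies behind this result, so the reading stays purely descriptive.

As far as these compounds go, whether a hydroxyl, an amine or a carboxylic acid in place of methoxy on this same carbon would give a step beyond the scatter remains open. Also open, from the compounds shown here alone, is whether a longer chain than pentyl, carrying the same methoxy, would read the same way in this assay.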